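Replacing the 4-methylpiperazin-1-yl group of compound 3

The source may report more compounds than this note shows. Statements on the series, on what has been measured and on what is new or still open speak of the compounds shown alone.

In an ADME assay on L02 cells (Homo sapiens) for inhibition, read by CCK-8 assay, with a stated time of 48 h (a lower number here means a stronger inhibitor of growth, a higher number a weaker inhibitor of growth), compound 1 `Cc1ccccc1Nc1nc(NC2CCCCC2)ncc1Cl` gives > 100000 nM, which is a limit and not a number. Compound 2 `Cc1ccccc1Nc1nc(Nc2ccccc2)ncc1Cl` gives > 100000 nM, which is also a limit. For the measured compounds named here, compound 3 `Cc1ccccc1Nc1nc(Nc2ccc(N3CCN(C)CC3)cn2)ncc1Cl` gives 5980 nM, the only true number measured so far.

Compound 4 `Cc1ccccc1Nc1nc(Nc2ccc(N3CCCCC3)cn2)ncc1Cl` departs from compound 3 in one place: piperidin-1-yl in place of 4-methylpiperazin-1-yl on an aromatic carbon. Piperidin-1-yl stands in place of 4-methylpiperazin-1-yl on an aromatic carbon, para to a large group.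

Going by the values given here, the only measured step is a step that the two limits leave unreadable from compound 1 to compound 2. Among the compounds with values here, it concerns a different place in the structure and offers no size to carry over, so no measured step bears directly on this change. With compound 3 at 5980 nM as the sole anchor, a modest move toward weaker inhibition of growth is expected in this assay, though only tentatively. The estimated change is a 1.7-fold higher number from compound 3 to compound 4 (0.22 log units; within the scatter). For compound 4 the estimated value is 10000 nM, with an expected range from 3000 nM to 40000 nM.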

Compound 4, concentration for 50% growth inhibition: 42400 nM
Beside the measured number, compound 4's estimate is 4.2-fold (0.63 log units) below it; measured number outside the range, above it.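

In this assay, the group on this aromatic carbon, two atoms from the ring nitrogen, clearly matters: piperidin-1-yl in place of 4-methylpiperazin-1-yl gives a 7.1-fold higher number from compound 3 to compound 4 (0.85 log units; beyond the scatter). For the compounds shown here, this is the first step with a readable size, as the earlier step between compound 1 and compound 2 cannot be read, and it goes with a change from a ring with 2 hetero atoms to one with 1 hetero atom. Compound 4 keeps a true number, so this step could be sized, unlike values at the limit of the assay: the limit of > 100000 nM in this assay, at which 2 of the 4 values shown sit.

The compounds shown do not separate the loss of the second ring nitrogen from the loss of its methyl group. They also leave open how an unsubstituted piperazin-1-yl or a morpholin-4-yl group would read at this place.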